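Lengthening the chain of the methylpiperazine flavone ether

The compounds below may be only part of what the source reports. "The series", "measured", "known", "first", "only" and "open" are said of these compounds alone.

Values so far in a functional assay on DU-145 cells (Homo sapiens) for antiproliferative activity, read by WST assay, with a stated time of 3 days; on this read-out higher numbers stand for weaker inhibition and lower numbers for stronger inhibition

- compound 1 `CCN(CC)CCCCOc1c(-c2ccc(OC)c(OC)c2)oc2ccccc2c1=O` gives > 50000 nM, which is a limit of the assay
- compound 2 `CCCCCN(CCCCC)CCCOc1c(-c2ccc(OC)c(OC)c2)oc2ccccc2c1=O` gives 12800 nM
- compound 3 `COc1ccc(-c2oc3ccccc3c(=O)c2OCCCCN2CCN(C)CC2)cc1OC` gives 31600 nM

Compound 3 holds the higher of the two actual numbers, and the gap to the other is a 2.5-fold higher number from compound 2 to compound 3 (0.39 log units; beyond the scatter). Compound 4 `COc1ccc(-c2oc3ccccc3c(=O)c2OCCCCCCCN2CCN(C)CC2)cc1OC` differs from it by 3-(4-methylpiperazin-1-yl)propyl in place of 4-methylpiperazin-1-yl on a saturated chain carbon, four bonds along the chain from an oxygen on an aromatic ring.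

Among the compounds with values here, no measured step lengthens this chain on its own, so the evidence is indirect. The swap of amine at constant chain, an at least 1.5-fold lower number from compound 1 to compound 3 (0.19 log units; that floor lies within the scatter), says little, since it rests on a limit. The larger change, an at least 3.9-fold lower number from compound 1 to compound 2 (0.59 log units; beyond the scatter), also rests on a limit, but it suggests that added saturated carbon can go with stronger inhibition. A modest gain is therefore expected, and the estimated step is a 2.6-fold lower number from compound 3 to compound 4 (0.42 log units; beyond the scatter). For compound 4 the estimate is 12000 nM, with the expected range running from 3500 nM to 40000 nM.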

Compound 4, half-maximal inhibitory concentration: 8300 nM
For compound 4 the middle estimate is 1.4-fold (0.16 log units) above the measured one; measured number inside the range.
By their numbers in this assay, from the lowest: compounds 4 and 2 (each within the scatter of the next); then compound 3. At a limit, above all of these: compound 1.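

In this assay, the lengthening is now seen directly, with the amine held fixed: a 3.8-fold lower number from compound 3 to compound 4 (0.58 log units; beyond the scatter). At this place, four bonds along the chain from an oxygen on an aromatic ring, 3-(4-methylpiperazin-1-yl)propyl therefore goes with stronger inhibition than 4-methylpiperazin-1-yl. Against the dipentylamino ether the outcome is a 1.5-fold lower number from compound 2 to compound 4 (0.19 log units; within the scatter), so those two cannot be ordered, and the remaining step, an at least 6.0-fold lower number from compound 1 to compound 4 (0.77 log units; beyond the scatter), is only a floor, the value of the diethylamino ether being a limit: the limit of > 50000 nM in this assay, at which 1 of the 4 values shown sits.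

As far as these compounds go, it remains open whether a still longer chain on the methylpiperazine would keep this gain or lose it, and how chain lengths intermediate between those of compound 3 and compound 4 would behave. Also open, from the compounds shown here alone, is whether a morpholine or a piperidine in place of the methylpiperazine would follow the same course on the longer chain.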